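An Acid in Place of an Amide on a Weak Inhibitor

A few compounds are considered here, and "the series" means these few. Any claim that something is new, unique, unknown or untested is made for them only; others in the source may bear on it.

Compound 1, `NC(=O)c1ccc(-c2cnc(C(O)CCc3ccc(-c4ccccc4)cc3)o2)nc1`, was examined in an assay for inhibition of Fatty-acid amide hydrolase 1 (Rattus norvegicus); on this read-out higher numbers stand for weaker inhibition and lower numbers for stronger inhibition. In this assay compound 1 gives > 1000 nM, which is a limit of the assay and not a number. The evidence for compound 1 is thus (the limit of > 1000 nM in this assay, at which 1 of the 3 values shown sits). The two other compounds carry a carbonyl where compound 1 carries a hydroxy group on the linker. Compound 2, `CN(C)C(=O)c1cnc(C(=O)CCc2ccc(Oc3ccccc3)cc2)o1`, in this assay gives 5.4 nM. Compound 3, `O=C(CCc1ccc(-c2ccccc2)cc1)c1ncc(-c2cccnc2)o1`, in this assay gives 1.1 nM.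

Compound 4, `O=C(O)c1ccc(-c2cnc(C(O)CCc3ccc(-c4ccccc4)cc3)o2)nc1`, differs from compound 1 in one place: hydroxy in place of amino on a carbonyl carbon, so that the carbamoyl group of compound 1 becomes a carboxy group in compound 4. Within the data shown here, no measured pair among compounds 1, 2 and 3 shows this exchange, so its effect cannot be read from the numbers in hand.

The expectation for compound 4 therefore rests on compound 1 alone, because in this assay compound 1 gives > 1000 nM. The step that the limit leaves unreadable from compound 1 to compound 4 is expected to be none beyond the scatter, with a lean toward weaker inhibition. Compound 4 is estimated at 3000 nM, in a range from 1000 nM to 30000 nM, most likely again reported only as a limit.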

Compound 4, inhibition constant: 10000 nM
Estimate against measurement, compound 4: 3.3-fold (0.52 log units) below; the range from low to high includes it.
By their numbers in this assay, from the lowest: compound 3; then compound 2; then compound 4.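

In this assay compound 1 gives > 1000 nM, which is a limit of the assay and not a number. Compound 4 gives 10000 nM. No step from compound 1 to compound 4 can be read, because the comparison rests on that limit: the limit of > 1000 nM in this assay, at which 1 of the 4 values shown sits.

The compounds shown leave open how far the exchange of carbamoyl for carboxy moves inhibition in this series.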